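This account rests on a few compounds, and the source may have more. Where it says the series, first, only, none or still open, it means among the compounds named here.

Measured compounds:
compound 1, `C=CCONC(=O)Cn1cc(C(=O)N[C@@H](C)C(=O)N[C@H](C(=O)O)C(C)C)c2ccccc21`, > 128000 nM
compound 2, `C=CCONC(=O)Cn1cc(C(=O)N[C@@H](C)C(=O)N[C@@H](CC(C)C)C(=O)O)c2ccccc21`, > 128000 nM
compound 3, `CC(C)[C@H](NC(=O)CNC(=O)c1cn(CC(=O)NOCc2ccccc2)c2ccccc12)C(=O)O`, > 128000 nM

In a functional assay on MRC5 cells (Homo sapiens) for inhibition, read by microscopy and resazurin assay, with a stated time of 72 h (a lower number here means a stronger inhibitor, a higher number a weaker inhibitor), compound 1 gives > 128000 nM, and this value is a limit of the assay rather than a number. Compound 2 gives > 128000 nM in this assay, again a limit rather than a number. Compound 3 gives > 128000 nM in this assay, which is likewise a limit and not a number. All three measured values therefore sit at the limit of > 128000 nM in this assay, at which 3 of the 3 values shown sit.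

Compound 1 and compound 2 differ by isobutyl in place of isopropyl on a saturated chain carbon bound to an amide-type nitrogen and a carbonyl carbon. The step that the two limits leave unreadable from compound 1 to compound 2 is left unreadable by the two limits. Compound 3 carries a different core from compound 1; the difference between the two cores is not broken down here.

Compound 4, `CC(C)C[C@H](NC(=O)CNC(=O)c1cn(CC(=O)NOCc2ccccc2)c2ccccc12)C(=O)O`, is not yet measured. It differs from compound 3 by isobutyl in place of isopropyl on a saturated chain carbon bound to an amide-type nitrogen and a carbonyl carbon, the same change as that from compound 1 to compound 2, since the place is the same word for word in both cases.

With every measured value in this assay resting at a limit, the change has not yet produced a readable number anywhere in the series. For compound 4 the expectation is a step that the limit leaves unreadable from compound 3 to compound 4 in this assay, that is, no readable movement, because the same change gave a step that the two limits leave unreadable from compound 1 to compound 2. Compound 4 is accordingly estimated at 200000 nM in this assay, with the expected range 60000 nM to 1000000 nM, and most likely the assay will again report only a limit.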

Compound 4, half-maximal inhibitory concentration: > 128000 nM
Compound 4 ended at the assay's limit; the forecaster's own chance of this, stated with the estimate: 90%; the middle value does not contradict the limit.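

In this assay compound 4 gives > 128000 nM as a limit of the assay, not a number. No step can be read between compound 3 and compound 4, as both rest at the same limit: the limit of > 128000 nM in this assay, at which 4 of the 4 values shown sit.

The compounds shown leave open whether isobutyl in place of isopropyl changes the value in this assay at all, and at what concentration any of the four compounds reaches half-maximal inhibition.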